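Alkene substituent change on the thienopyrimidine-free core series

A few compounds are considered here, and "the series" means these few. Any claim that something is new, unique, unknown or untested is made for them only; others in the source may bear on it.

Going by the values given here, compound 2 `C/C=C/C(=O)Nc1cccc(Oc2nc(Nc3cccc(C#N)c3)nc3ccsc23)c1` is the only member of the set with a numeric result: in a functional assay on A549 cells (Homo sapiens) for inhibition, read by MTT assay, with a stated time of 72 h (a higher number here means a weaker inhibitor, a lower number a stronger inhibitor), compound 2 gives 11300 nM. Compound 1 `COc1ccc(Nc2nc(Oc3cccc(NC(=O)/C=C/C(C)C)c3)c3sccc3n2)cn1` returns only a limit in this assay, > 50000 nM, so nothing can be said of its size beyond (the limit of > 50000 nM in this assay, at which 1 of the 2 values shown sits). Compound 3 `CC(C)/C=C/C(=O)Nc1cccc(Oc2nc(Nc3cccc(C#N)c3)nc3ccsc23)c1` has not been measured. It differs from compound 2 by isopropyl in place of methyl on a double-bonded chain carbon bound to a double-bonded chain carbon. Compound 1 carries the same 3-methylbut-1-en-1-yl chain on a different amine portion and reaches no number. Among the compounds with values here, no measured pair isolates this chain change. Compound 3 is expected to be weaker than its methyl partner, with an estimated 22000 nM spanning 7000 nM to 60000 nM, which corresponds to an expected step of a 1.9-fold higher number from compound 2 to compound 3 (0.29 log units; within the scatter); a limit read-out remains a real possibility.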

Compound 3, half-maximal inhibitory concentration: 19000 nM
The estimate for compound 3 lay 1.2-fold (0.06 log units) above the measured number; the measured number falls inside the stated range.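

In this assay the change of isopropyl in place of methyl on a double-bonded chain carbon bound to a double-bonded chain carbon now has a measured size: a 1.7-fold higher number from compound 2 to compound 3 (0.23 log units; within the scatter) leaves compound 2 and compound 3 indistinguishable on the 3-cyanophenyl amine portion. The 3-methylbut-1-en-1-yl chain is thus compatible with a numeric read-out, and with that chain held fixed, an at least 2.6-fold lower number from compound 1 to compound 3 (0.42 log units; beyond the scatter) goes with 3-cyanophenyl in place of 6-methoxypyridin-3-yl on a nitrogen on an aromatic ring. Compound 1 remains a limit and not a number: the limit of > 50000 nM in this assay, at which 1 of the 3 values shown sits.

On these data alone, whether a longer chain or a terminal dimethylamino group at this chain end would shift the number beyond the scatter stays open. Also open, as far as these compounds go, is how the prop-1-en-1-yl chain behaves on the 6-methoxypyridin-3-yl amine portion.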